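Sulfonyl pyridine swap on the shared core

A few compounds are considered here, and "the series" means these few. Any claim that something is new, unique, unknown or untested is made for them only; others in the source may bear on it.

Compound 1 `CNCc1cn(S(=O)(=O)c2ccccn2)c(-c2cccnc2F)c1F`, compound 2 `CNCc1cn(S(=O)(=O)c2cccc(OC)n2)c(-c2cccnc2F)c1F`, compound 3 `CNCc1cn(S(=O)(=O)c2cccc(F)n2)c(-c2cccnc2F)c1F` and compound 4 `CNCc1cn(S(=O)(=O)c2cncc(F)c2)c(-c2cccnc2F)c1F` share one core. In a functional assay on the whole organism (strain Jcl:Sprague-Dawley) for inhibition, with Rattus norvegicus as the target, with stated times of 3 min and 3 h, at a dose of 1 mg/kg by the intravenous route (a higher number here means more inhibition at the dose given (going by the name of the read-out), a lower number less inhibition), compound 1 gives 95%, and compound 2 gives 98%. Within the data shown here, the only measured step, a number 3 percentage points higher from compound 1 to compound 2 (within the scatter), is a methoxy in place of hydrogen on an aromatic carbon and stays within the scatter. In this assay compound 3 is reported as "not determined" (no result reported), so its standing among the others cannot be fixed from the numbers. Compound 4 differs from compound 3 by 5-fluoropyridin-3-yl in place of 6-fluoropyridin-2-yl on a sulfonyl sulfur. Among the measured compounds shown here, no measured step covers this change; the only guide is that compound 1 and compound 2 both give numbers on the same level and the single measured change stayed within the scatter. Compound 4 is therefore expected near 85%, with a range from 55% to 99%.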

Compound 4, a percentage reported as inhibition, in the whole organism at one dose (the size of the read-out at that dose, not a potency): 99%
Compound 4: middle estimate off by 14 percentage points, on the low side, within the range that was stated.
By their numbers in this assay, from the lowest: compounds 1, 2 and 4 (each within the scatter of the next).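

In this assay, 5-fluoropyridin-3-yl on the sulfonyl sulfur gives a number 1 percentage points higher from compound 2 to compound 4 (within the scatter), and a number 4 percentage points higher from compound 1 to compound 4 (within the scatter). The position therefore accepts a change from a pyridin-2-yl group to a pyridin-3-yl group, a larger change than the earlier methoxy for hydrogen swap, with no step beyond the scatter. No measured data bear on why this change leaves the read-out on the same level.

With no result for compound 3, 6-fluoropyridin-2-yl and 5-fluoropyridin-3-yl cannot be compared directly. As far as these compounds go, whether an amine or a carboxylic acid on the pyridine ring would hold this level remains open.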